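The source may report more compounds than this note shows. Statements on the series, on what has been measured and on what is new or still open speak of the compounds shown alone.

Working notes on the hydrazone series.

Compound 1 `O=C(N/N=C/c1cccnc1)c1cccnc1Nc1cccc(C(F)(F)F)c1` and compound 2 `O=C(N/N=C/c1ccncc1)c1cccnc1Nc1cccc(C(F)(F)F)c1` share one core; compound 3 `CNc1ncccc1C(=O)N/N=C/c1cccnc1` carries another, and the difference between the two cores is not broken down here. In a functional assay on the whole organism (strain Wistar) for inhibition, with Rattus norvegicus as the target, read by paw edema, with a stated time of 4 h, at a dose of 10 mg/kg by the intraperitoneal route (on this read-out lower numbers stand for less inhibition and higher numbers for more inhibition at the one dose given (going by the name of the read-out)), compound 1 gives 36%. In this assay compound 2 gives 45.9%. The change between them is pyridin-4-yl in place of pyridin-3-yl on a carbon with a double bond to nitrogen, and it made a step of a number 9.9 percentage points higher from compound 1 to compound 2 (within the scatter), so the two numbers are not told apart by this read-out. In this assay compound 3 gives 13.8%, the lowest of the three numbers, lying beyond the scatter from both compound 1 and compound 2.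

Compound 4 `CNc1ncccc1C(=O)N/N=C/c1ccncc1` is not yet measured. It differs from compound 3 by pyridin-4-yl in place of pyridin-3-yl on a carbon with a double bond to nitrogen, the same change as that between compound 1 and compound 2, on the same kind of place, word for word; the change thus occurs twice among the compounds shown. Carried over to the core of compound 3, the expected step is a number 7.2 percentage points higher from compound 3 to compound 4 (within the scatter). This rests on the earlier step, a number 9.9 percentage points higher from compound 1 to compound 2 (within the scatter), being within the scatter, and on compound 3 starting from 13.8%, so that no large rise is expected. Compound 4 is expected to give 21% in this assay, with a plausible range from 8% to 36%.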

Compound 4, a percentage reported as inhibition, in the whole organism at one dose (the size of the read-out at that dose, not a potency): 15.5%
Estimate against measurement, compound 4: 5.5 percentage points above, within the range that was stated.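

In this assay, pyridin-4-yl in place of pyridin-3-yl on a carbon with a double bond to nitrogen gives a number 1.7 percentage points higher from compound 3 to compound 4 (within the scatter) on the core of compound 3, so this read-out does not tell compound 3 and compound 4 apart, just as it did not tell compound 1 and compound 2 apart. Set side by side, the two steps do not differ, and the change reads alike on both cores: the same change on two cores in this assay, a number 9.9 percentage points higher (within the scatter) from compound 1 to compound 2 and a number 1.7 percentage points higher (within the scatter) from compound 3 to compound 4, 8.2 percentage points apart, within the scatter of two such steps. Among the compounds shown here, this shows only that the swap between the two pyridinyl groups gave no step beyond the scatter on either core; it does not show a real rise that carries over from one core to the other, and two cores at a single dose say nothing about a third core or about potency.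

Open, from the compounds shown here alone, is whether any other group on that carbon, such as a plain phenyl ring or a chain ending in a carboxylic acid or an amine, would move the read-out beyond the scatter on either core. Also open is which part of the difference between the two cores goes with the lower numbers of compound 3 and compound 4, since no pair shown differs in only one place across the two cores.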